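Swapping Methyl for Fluoro on Compound 1

The source may report more compounds than this note shows. Statements on the series, on what has been measured and on what is new or still open speak of the compounds shown alone.

Of the compounds shown here, three have been tested in an assay on isolated protein for inhibition of Aromatase (Homo sapiens), read by fluorescence, using NADPH, with a stated time of 30 min, tested at 50 uM; a higher number here means more inhibition at the concentration tested (going by the name of the read-out), a lower number less inhibition. Compound 1 (`Cc1ccc(-c2cc3ccccc3[nH]2)cc1`) gives 9.33% in this assay and stands lowest of the three. Compound 2 (`Cn1c(-c2ccc(Cl)c(Cl)c2)cc2cc(N)ccc21`) gives 42%, a number well beyond the scatter above compound 1, and compound 3 (`N#Cc1ccc2[nH]c(-c3ccccc3)cc2c1`) gives 82.3%, the highest figure seen, again far beyond the scatter.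

The next compound, compound 4 (`Fc1ccc(-c2cc3ccccc3[nH]2)cc1`), differs from compound 1 in a single place: fluoro in place of methyl on an aromatic carbon. This means a fluoro in place of methyl on an aromatic carbon, para to a group of 9 heavy atoms, with no change to ring count, hydrogen-bond donors or acceptors, or charge.

Among the measured compounds shown here, no measured pair among the three compounds makes this same change, so there is no direct precedent to lean on. The change is small in size, and the step from compound 1 to compound 4 is expected to be a number 5.7 percentage points higher from compound 1 to compound 4 (within the scatter), most likely within the usual scatter in this assay. Compound 4 is therefore estimated to give 15% in this assay, within a range from 3% to 35%.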

Compound 4, a percentage reported as inhibition, at one concentration (the size of the read-out at that concentration, not a potency): 21.8%
For compound 4 the middle estimate is 6.8 percentage points below the measured one, and the stated range covers the measured number.
By their numbers in this assay, from the lowest: compound 1; then compound 4; then compound 2; then compound 3.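

In this assay, among the compounds shown here, placing fluoro in place of methyl gives a number 12.5 percentage points higher from compound 1 to compound 4 (beyond the scatter), the first step here that compares two compounds differing in only one place. It shows that this position, on an aromatic carbon para to a group of 9 heavy atoms, responds to the group it carries, even when one heavy atom replaces another with no change in hydrogen-bond donors, hydrogen-bond acceptors or net charge. No available measurement bears on the reason for this modest step.

From the compounds shown here alone, whether the same position would give a larger or smaller number with an amine, a methoxy group or a trifluoromethyl group remains open. Also open, going by these compounds, is whether fluoro in place of methyl would give a step of similar size on the core of compound 3 or another core.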